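Swapping chloro for fluoro in a growth-inhibition series

The source may hold more compounds than are shown below. What is called first, only, known or untested is meant among the compounds shown, and "the series" means these compounds.

- Compound 1 `O=S(=O)(Nc1ccc(Br)c(Cl)c1)c1ccc(-c2cnc(C3CC3)o2)cc1`: 491 nM
- Compound 2 `Cc1cc(Cl)cc(NS(=O)(=O)c2ccc(-c3cnc(C4CC4)o3)cc2)c1`: 175 nM

In a functional assay on cells (leukaemia cell line, Homo sapiens) for inhibition, read by sulforhodamine B assay, with a stated time of 48 h (a lower number here means a stronger inhibitor of growth, a higher number a weaker inhibitor of growth), compound 2 holds the lower of the two numbers. Going by the values given here, the only measured step, a 2.8-fold lower number from compound 1 to compound 2 (0.45 log units; beyond the scatter), is modest, and it also changed the group on the sulfonamide nitrogen. Compound 3 `Cc1cc(F)cc(NS(=O)(=O)c2ccc(-c3cnc(C4CC4)o3)cc2)c1` differs from compound 2 in one place: fluoro in place of chloro on an aromatic carbon. Among the compounds with values here, no measured pair shows this exact swap, so that modest step is the only guide to size. A small step toward a higher number is expected, no larger than the measured one. The expected change is a 1.7-fold higher number from compound 2 to compound 3 (0.23 log units; within the scatter). For compound 3 the estimate is 300 nM, within an expected range of 120 nM to 700 nM.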

Compound 3, concentration for 50% growth inhibition: 138 nM
The estimate for compound 3 lay 2.2-fold (0.34 log units) above the measured number; the range from low to high includes it.
By their numbers in this assay, from the lowest: compounds 3 and 2 (each within the scatter of the next); then compound 1.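

At this place on the ring, fluoro in place of chloro gives a 1.3-fold lower number from compound 2 to compound 3 (0.10 log units; within the scatter) in this assay, so the halogen can be exchanged here without a change beyond the scatter. The 3-fluoro-5-methylphenyl group keeps the gain over the group in compound 1, with a 3.6-fold lower number from compound 1 to compound 3 (0.55 log units; beyond the scatter), so this modest separation does not depend on chloro. No evidence is available to explain these results. Going by these compounds, whether a methoxy group, an amine or a nitrile at this place would also stay within the scatter remains open, as does the contribution of the methyl group.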